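The compounds below may be only part of what the source reports. "The series", "measured", "known", "first", "only" and "open" are said of these compounds alone.

Measured in an ADME assay (liver) for metabolic stability, with Liver microsome (Homo sapiens) as the target, using microsomes and NADPH, with a stated time of 30 min, tested at 1 uM; on this read-out higher numbers stand for fast clearance and lower numbers for slow clearance:
Compound 1 `Nc1ccc(S(=O)(=O)N2CCN(c3ncc(C(O)(C(F)(F)F)C(F)(F)F)cc3C3CC3)CC2)cn1`: 38 mL.min-1.g-1
Compound 2 `COCC#Cc1cc(C(O)(C(F)(F)F)C(F)(F)F)cnc1N1CCN(S(=O)(=O)c2ccc(N)nc2)CC1`: 15 mL.min-1.g-1
Compound 3 `Nc1ccc(S(=O)(=O)N2CCN(c3ncc(C(O)(C(F)(F)F)C(F)(F)F)cc3-c3cccnc3)CC2)cn1`: 17 mL.min-1.g-1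

These three compounds differ in one group on an aromatic carbon: cyclopropyl in compound 1, 3-methoxyprop-1-yn-1-yl in compound 2 and pyridin-3-yl in compound 3. Compound 1 has the highest number of the three. Compound 3 cannot be told apart from compound 2, as the data show a 1.1-fold higher number from compound 2 to compound 3 (0.05 log units; within the scatter).

Compound 4 `COc1cncc(-c2cc(C(O)(C(F)(F)F)C(F)(F)F)cnc2N2CCN(S(=O)(=O)c3ccc(N)nc3)CC2)c1` keeps all of compound 3 except for one change, from pyridin-3-yl to 5-methoxypyridin-3-yl. This puts methoxy in place of hydrogen on an aromatic carbon.

Among the compounds with values here, no measured step makes this exact change, so the evidence is indirect. The two modest steps, a 2.5-fold lower number from compound 1 to compound 2 (0.40 log units; beyond the scatter) and a 2.2-fold lower number from compound 1 to compound 3 (0.35 log units; beyond the scatter), both replace the whole cyclopropyl group. The change in compound 4 leaves the pyridin-3-yl ring in place and adds only a small group to it. Compound 2 also carries a methoxy group and gives 15 mL.min-1.g-1. No step beyond the scatter is therefore expected in this assay, and three compounds cannot settle the direction. The expected change is a 1.2-fold higher number from compound 3 to compound 4 (0.07 log units; within the scatter). For compound 4 the estimated value is 20 mL.min-1.g-1, with an expected range from 11 mL.min-1.g-1 to 36 mL.min-1.g-1.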

Compound 4, intrinsic clearance in microsomes: 44 mL.min-1.g-1
Beside the measured number, compound 4's estimate is 2.2-fold (0.34 log units) below it, and the stated range ends below it.
By their numbers in this assay, from the lowest: compounds 2 and 3 (each within the scatter of the next); then compounds 1 and 4 (each within the scatter of the next).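

In this assay this position proves sensitive to a small addition: methoxy, only 2 heavy atoms, placed on the pyridin-3-yl ring two atoms from the ring nitrogen, gives a 2.6-fold higher number from compound 3 to compound 4 (0.41 log units; beyond the scatter) as a step beyond the scatter. The replacement of cyclopropyl by pyridin-3-yl therefore no longer looks like a lasting gain, since the data show a 1.2-fold higher number from compound 1 to compound 4 (0.06 log units; within the scatter) within the scatter, while a 2.9-fold higher number from compound 2 to compound 4 (0.47 log units; beyond the scatter) shows that compound 4 also stands apart from the methoxy-bearing alkyne compound. No measurement here accounts for why the added methoxy shifts the clearance number.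

From the compounds shown here alone, whether a methyl, a fluorine or an amine on the same ring carbon would shift the number as methoxy does stays open, so the shift cannot yet be tied to methoxy itself rather than to any added group. Also open is whether methoxy on another carbon of the pyridin-3-yl ring would give the same result, since the compounds shown carry it at only this one place.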